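The compounds below may be only part of what the source reports. "The series", "measured", "known", "first", "only" and "open" are said of these compounds alone.

In a functional assay on brain (Rattus norvegicus, strain Wistar) for inhibition (a higher number here means a weaker inhibitor, a lower number a stronger inhibitor), compound 1 (`CCCCOc1ccc(-c2c(C)[nH]c(=O)n2C2CCCCC2)cc1`) gives 13900 nM and compound 2 (`Cc1[nH]c(=O)n(C)c1-c1ccc(CC(C)C)cc1`) gives 7800 nM. Within the data shown here, these two values lie within the scatter of each other, so compound 2 stands level with the only other measured compound. Compound 3 (`CCCCCCCc1ccc(-c2c(C)[nH]c(=O)n2C)cc1`) has hexyl in place of isopropyl on a saturated chain carbon bound to an aromatic carbon. Among the measured compounds shown here, no measured pair shows a change of this kind, so the expectation is tentative. A modest move toward a lower number is expected, estimated as a 2.0-fold lower number from compound 2 to compound 3 (0.29 log units; within the scatter). In this assay the estimated value for compound 3 is 4000 nM, with an expected range from 1000 nM to 15000 nM.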

Compound 3, half-maximal inhibitory concentration: 8400 nM
Compound 3: the middle estimate sits 2.1-fold (0.32 log units) below what was measured, and the stated range covers the measured number.
By their numbers in this assay, from the lowest: compounds 2, 3 and 1 (each within the scatter of the next).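

Hexyl in place of isopropyl on a saturated chain carbon bound to an aromatic carbon gives a 1.1-fold higher number from compound 2 to compound 3 (0.03 log units; within the scatter) in this assay, the first step that can be read at this position. Here, the larger all-carbon group leaves the number level, so this single pair shows no gain from added chain length. No measurement at hand accounts for this flat step.

Open, going by these compounds, is whether any group other than a plain carbon chain at this position, such as an amine or a carboxylic acid, would move the number beyond the scatter.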